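The compounds below may be only part of what the source reports. "The series", "measured", "known", "first", "only" and "open" are said of these compounds alone.

Working notes on the series.

Compound 1 `Nc1ccnc(-c2nn(Cc3ccccc3F)c3ncccc23)n1` is measured in a functional assay (aorta) with Oryctolagus cuniculus as the target (a higher number here means a weaker inhibitor, a lower number a stronger inhibitor), with two entries, 270 nM; 265000 nM (2 entries), and the spread between them is far beyond the usual scatter; the two values of compound 1 are simply recorded side by side the several entries of compound 1 in this assay, 270 nM; 265000 nM (2 entries) without a way to prefer one. Among the compounds with values here, compound 2 `N#CCCCCCc1cnc(-c2nn(Cc3ccccc3F)c3ncccc23)nc1N` carries the shared core with a chain ending in a nitrile, and in this assay compound 2 gives 588000 nM, the only number for it; a further entry for compound 2 exists without a single number. Within the data shown here, no step between measured compounds that differ in one place is available, so compound 2 stands alone on its number.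

Compound 3 `CC(C#N)CCCCCc1cnc(-c2nn(Cc3ccccc3F)c3ncccc23)nc1N` differs from compound 2 by 1-cyanoethyl in place of cyano on a saturated chain carbon, five bonds along the chain from an aromatic carbon, in words 1-cyanoethyl in place of cyano on a saturated chain carbon, five bonds along the chain from an aromatic carbon. Among the measured compounds shown here, with no measured step to lean on, the expectation for this change is none beyond the scatter in this assay, in either direction. The step from compound 2 to compound 3 is therefore estimated as a 1.1-fold lower number from compound 2 to compound 3 (0.03 log units; within the scatter). For compound 3 the expected value in this assay is 550000 nM, with a range from 150000 nM to 2000000 nM.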

Compound 3, half-maximal inhibitory concentration: 1290000 nM
Compound 3: middle estimate off by 2.3-fold (0.37 log units), on the low side; measured number inside the range.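

At the saturated chain carbon five bonds along the chain from an aromatic carbon, 1-cyanoethyl in place of cyano gives a 2.2-fold higher number from compound 2 to compound 3 (0.34 log units; beyond the scatter) in this assay, so this change is not silent at this position and moves the series towards weaker inhibition. Both groups keep a nitrile, and the hydrogen-bond donors and acceptors counted for them are the same, so the difference between them lies in the carbon count of the group and not in those features. The step is only modest, and it should be read with care, as entries for a single compound in this series can lie far apart: the several entries of compound 1 in this assay, 270 nM; 265000 nM (2 entries)

Going by these compounds, how a chain ending in an amine or a carboxylic acid would read in this assay stays open, as does the reading for a longer chain ending in a nitrile. Also open, on these data alone, is whether the higher number follows the branching carbon of 1-cyanoethyl itself, which a single step on one chain length cannot separate from the added size of the group.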